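The source may report more compounds than this note shows. Statements on the series, on what has been measured and on what is new or still open speak of the compounds shown alone.

Series notes. Compound 1 `O/N=C(/CCN1CCN(c2ccccn2)CC1)c1ccccc1Cl` and compound 2 `Cc1ccccc1/C(CCN1CCN(c2ccccn2)CC1)=N\O` share one core, while compound 3 `CO/N=C(\CCN1CCN(c2ccccn2)CC1)c1ccccc1Cl` and compound 4 `CO/N=C(\CCN1CCN(c2ccccn2)CC1)c1ccccc1C` share another. How the two cores differ is not broken down here. In a functional assay on HEK293 cells with D(4) dopamine receptor (Homo sapiens) as the target, read by FLIPR (a lower number here means that less compound is needed, a higher number that more compound is needed for the effect), compound 1 gives 25 nM. In this assay compound 2 gives 20.3 nM. The change from compound 1 to compound 2 is methyl in place of chloro on an aromatic carbon and made a 1.2-fold lower number from compound 1 to compound 2 (0.09 log units; within the scatter). In this assay compound 3 gives 42.3 nM, which sits within the scatter of compound 1 but beyond the scatter of compound 2. The change from compound 3 to compound 4 is methyl in place of chloro on an aromatic carbon; its place reads word for word as in the earlier pair, so it is the same change carried onto the other core. For compound 4 the step of a 1.2-fold lower number from compound 3 to compound 4 (0.08 log units; within the scatter) is expected to be small. Among the compounds with values here, this expectation rests only on compound 1 and compound 2, whose step a 1.2-fold lower number from compound 1 to compound 2 (0.09 log units; within the scatter) stayed within the scatter, and no second example of the change is available. Compound 4 is therefore estimated at 35 nM in this assay, with a range from 18 nM to 70 nM.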

Compound 4, half-maximal effective concentration: 74 nM
The estimate for compound 4 lay 2.1-fold (0.33 log units) below the measured number; measured number outside the range, above it.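

In this assay, methyl in place of chloro on the second core gives a 1.7-fold higher number from compound 3 to compound 4 (0.24 log units; within the scatter), so on this core, as on the first, the step stays within the scatter. Set side by side, the two steps cannot be told apart: the same change on two cores in this assay, a 1.2-fold lower number (0.09 log units; within the scatter) from compound 1 to compound 2 and a 1.7-fold higher number (0.24 log units; within the scatter) from compound 3 to compound 4, 2.2-fold (0.33 log units) apart, within the scatter of two such steps This fits the change carrying across these two cores in this assay, with little effect on either, but it rests on a single pair per core and does not show that the change has a consistent direction or that the two cores would respond alike to a change with a larger step.

The compounds shown leave open whether other groups at this place on the aromatic ring, such as fluoro, methoxy or trifluoromethyl, would give steps beyond the scatter on either core. Also open, from the compounds shown here alone, is whether the chloro-to-methyl change would carry over in the same way to a core bearing an amine or a carboxylic acid.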